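Swapping 4-(dimethylamino)phenyl for 3-bromophenyl: compound 4 awaits its number

The source may hold more compounds than are shown below. What is called first, only, known or untested is meant among the compounds shown, and "the series" means these compounds.

Of the compounds shown here, three built on a shared core have been measured in a functional assay on SK-N-SH cells (Homo sapiens) for cytotoxicity, read by MTT assay, with a stated time of 24 h; a lower number here means a stronger inhibitor, a higher number a weaker inhibitor. Compound 1 (`C/C(=N\NC(=O)/C(C#N)=C/c1ccccc1)c1c(O)c2ccc(O)cc2oc1=O`) gives 13500 nM, and compound 2 (`COc1cc(/C=C(\C#N)C(=O)N/N=C(\C)c2c(O)c3ccc(O)cc3oc2=O)cc(OC)c1OC`) gives 14600 nM. Compound 3 (`C/C(=N\NC(=O)/C(C#N)=C/c1ccc(N(C)C)cc1)c1c(O)c2ccc(O)cc2oc1=O`) gives 6090 nM, the lowest of the three numbers and so the best-placed of the set in this assay. Among the compounds with values here, only one measured pair differs in a single place: dimethylamino in place of hydrogen on an aromatic carbon gives a 2.2-fold lower number from compound 1 to compound 3 (0.35 log units; beyond the scatter).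

Compound 4 (`C/C(=N\NC(=O)/C(C#N)=C/c1cccc(Br)c1)c1c(O)c2ccc(O)cc2oc1=O`) departs from compound 3 at that same aryl group: 3-bromophenyl in place of 4-(dimethylamino)phenyl on a double-bonded chain carbon bound to a double-bonded chain carbon. In words, this is 3-bromophenyl in place of 4-(dimethylamino)phenyl on a double-bonded chain carbon bound to a double-bonded chain carbon. Within the data shown here, no measured compound carries bromine, so the effect of that atom is unknown. Compound 4 does lack the dimethylamino group, however, so the expectation leans on reversing a 2.2-fold lower number from compound 1 to compound 3 (0.35 log units; beyond the scatter). A modest move towards a higher number is therefore expected, of about that size. The expected change is a 2.1-fold higher number from compound 3 to compound 4 (0.31 log units; beyond the scatter). For compound 4 the estimated value is 12500 nM, with an expected range from 6000 nM to 26000 nM.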

Compound 4, half-maximal inhibitory concentration: 31300 nM
Compound 4: the middle estimate sits 2.5-fold (0.40 log units) below what was measured; measured number above the stated range.
By their numbers in this assay, from the lowest: compound 3; then compounds 1 and 2 (each within the scatter of the next); then compound 4.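

In this assay, the swap at this aryl group gives a 5.1-fold higher number from compound 3 to compound 4 (0.71 log units; beyond the scatter) and shows that the number at this position can move well upward as well as downward. Bromo in place of hydrogen on an aromatic carbon gives a 2.3-fold higher number from compound 1 to compound 4 (0.37 log units; beyond the scatter) and so the change is more than the loss of dimethylamino: the unsubstituted phenyl of compound 1 lies between the two, with a 2.2-fold lower number from compound 1 to compound 3 (0.35 log units; beyond the scatter) on one side and the bromo step on the other, both beyond the scatter. Nothing available accounts for why these two groups pull the number in opposite directions.

Because 3-bromophenyl and 4-(dimethylamino)phenyl differ in both the group and its numbered ring place, the compounds shown cannot separate the identity of the group from where it sits, and it remains open whether bromo would raise the number as it does here if it stood where dimethylamino stands in compound 3. Going by these compounds, it is also open whether a primary amine or a carboxylic acid on this phenyl ring would follow dimethylamino, follow bromo, or do neither.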